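A few compounds are considered here, and "the series" means these few. Any claim that something is new, unique, unknown or untested is made for them only; others in the source may bear on it.

Measured in a functional assay on HCT-116 cells (Homo sapiens) for antiproliferative activity, read by MTT assay, with a stated time of 48 h; a lower number here means a stronger inhibitor, a higher number a weaker inhibitor:
- compound 1 `COc1ccc(-c2cncc3[nH]c(=O)n(Cc4cc(OC)c(OC)c(OC)c4)c23)cc1O`: > 20000 nM, a limit
- compound 2 `COc1ccc(-c2cc3c(cn2)[nH]c(=O)n3-c2cc(OC)c(OC)c(OC)c2)cc1O`: 340 nM
- compound 3 `COc1ccc(-n2c(=O)[nH]c3cnc(-c4cc(OC)c(OC)c(OC)c4)cc32)cc1O`: > 20000 nM, a limit

Going by the values given here, compound 2 at 340 nM gives the only true number in this assay. The entries for compound 1 and compound 3 are limits. Compound 4 `COc1ccc(-c2cc3c(cn2)[nH]c(=O)n3-c2cc(OC)c(OC)c(OC)c2)cc1C(=O)O` keeps the core of compound 2 and alters one group: carboxy in place of hydroxy on an aromatic carbon. This places carboxy in place of hydroxy on an aromatic carbon, ortho to a methoxy group. Among the compounds with values here, no step between measured compounds sizes this change. A weakening beyond the scatter is expected, with the limit of > 20000 nM in this assay, at which 2 of the 3 values shown sit, as the nearest reference. The estimated 12-fold higher number from compound 2 to compound 4 (1.07 log units; beyond the scatter) is a large loss. Compound 4 is expected at 4000 nM, with an estimated range of 700 nM to 20000 nM.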

Compound 4, half-maximal inhibitory concentration: 3070 nM
Compound 4: the middle estimate sits 1.3-fold (0.11 log units) above what was measured; measured number inside the range.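

The position held by hydroxy on the 3-hydroxy-4-methoxyphenyl group now has its first measured step: in this assay, carboxy in its place gives a 9.0-fold higher number from compound 2 to compound 4 (0.96 log units; beyond the scatter). So this aromatic carbon, ortho to a methoxy group, accepts carboxy at a real cost in potency, yet compound 4 still gives a true number. This change does not carry the series to the limit, which remains a limit and not a number: the limit of > 20000 nM in this assay, at which 2 of the 4 values shown sit.

On these data alone, whether the step belongs to carboxy itself or to any larger group here remains open. A methyl ester, a primary amide or an amine on the same carbon would separate these readings.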